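This account rests on a few compounds, and the source may have more. Where it says the series, first, only, none or still open, it means among the compounds named here.

Measured in an ADME assay on the whole organism (plasma) for pharmacokinetics, with Rattus norvegicus as the target, with a stated time of 6 h, at a dose of 10 mg/kg by the oral route; on this read-out lower numbers stand for lower exposure and higher numbers for higher exposure at the dose given:
- compound 1 `Nc1cccc(CS(=O)(=O)N2CCN(c3cnn(-c4cc(F)cc(F)c4)c(=O)c3OC3CCCC3)CC2)c1`: 5700 ng.h/mL
- compound 2 `CC1(COc2c(N3CCN(S(=O)(=O)Cc4ccc(N)cc4)CC3)cnn(-c3cccc(Cl)c3)c2=O)CC1`: 8100 ng.h/mL

Compound 2, at 8100 ng.h/mL, and compound 1, at 5700 ng.h/mL, lie within the usual scatter of each other, so these two numbers set no order between them. Among the measured compounds shown here, both sit in the same range of exposure, and that range is the only guide available.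

Compound 3 `CC1(COc2c(N3CCN(S(=O)(=O)Cc4cccc(N)c4)CC3)cnn(-c3cccc(Cl)c3)c2=O)CC1` has the same atoms as compound 2, joined differently: 3-aminophenyl in place of 4-aminophenyl on a saturated chain carbon bound to a sulfonyl sulfur. For the measured compounds named here, no measured pair isolates this change, so its size in this assay cannot be read from the data, and no step beyond the scatter is expected.

The expected change is a 1.2-fold lower number from compound 2 to compound 3 (0.10 log units; within the scatter), which stays within the scatter. The estimate for compound 3 is 6500 ng.h/mL, with an expected range of 2800 ng.h/mL to 15000 ng.h/mL.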

Compound 3, area under the concentration-time curve: 5700 ng.h/mL
Estimate against measurement, compound 3: 1.1-fold (0.06 log units) above, within the range that was stated.
By their numbers in this assay, from the lowest: compounds 1, 3 and 2 (each within the scatter of the next).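

In this assay, 3-aminophenyl in place of 4-aminophenyl on a saturated chain carbon bound to a sulfonyl sulfur gives a 1.4-fold lower number from compound 2 to compound 3 (0.15 log units; within the scatter), and this pair is the only one shown that isolates this position. On this read-out, the two aminophenyl isomers are therefore not separated, so the data set no preference between them at this dose. Nothing available gives a cause for this result.

Going by these compounds, whether 2-aminophenyl, or a carboxylic acid or methoxy group in place of the amine on this ring, would read apart from compound 2 and compound 3 remains open. Compound 1 differs from compound 3 in more than one place, so it gives no separate reading of any single group in the rest of the molecule.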